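Difluorophenyl Chalcone Variant of a Trimethoxyphenyl Pyrazole

The source may report more compounds than this note shows. Statements on the series, on what has been measured and on what is new or still open speak of the compounds shown alone.

Measured compounds:
compound 1 `COc1cc(-c2cc(/C=C/C(=O)c3ccc(N)cc3)[nH]n2)cc(OC)c1OC`: 89%
compound 2 `COc1ccc(C(=O)/C=C/c2cc(-c3cc(OC)c(OC)c(OC)c3)n[nH]2)cc1`: 95%

In a functional assay on OVCAR-5 cells (Homo sapiens) for cytotoxicity, read by sulforhodamine B assay, with a stated time of 48 h, tested at 1 uM (a higher number here means a weaker effect of the compound at the concentration tested, a lower number a stronger effect), compound 2 gives 95%, the highest of the two numbers recorded. Compound 1 stands nearest, with the step of a number 6 percentage points higher from compound 1 to compound 2 (within the scatter), which keeps both compounds at a weak effect at the concentration tested.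

Compound 3 `COc1cc(-c2cc(/C=C/C(=O)c3ccc(F)c(F)c3)[nH]n2)cc(OC)c1OC` has not been measured. It differs from compound 2 in one place: 3,4-difluorophenyl in place of 4-methoxyphenyl on a carbonyl carbon.

Going by the values given here, only the step from compound 1 to compound 2 is known, and it concerns a different exchange on the same ring; it was small and within the scatter. Among the compounds with values here, no measured step shows what the exchange of 4-methoxyphenyl for 3,4-difluorophenyl does here. With both measured compounds showing weak effects, compound 3 is expected to stay in the same region, with an expected step of a number 5 percentage points lower from compound 2 to compound 3 (within the scatter) in this assay, not beyond the scatter. Compound 3 is therefore estimated at 90%, between 72% and 102%.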

Compound 3, a percentage reported as activity, at one concentration (the size of the read-out at that concentration, not a potency): 92%
The estimate for compound 3 lay 2 percentage points below the measured number; low and high end bracket the measured number.
By their numbers in this assay, from the lowest: compounds 1, 3 and 2 (each within the scatter of the next).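

In this assay, 3,4-difluorophenyl on the carbonyl carbon gives a number 3 percentage points lower from compound 2 to compound 3 (within the scatter), and the exchange for the 4-aminophenyl group gives a number 3 percentage points higher from compound 1 to compound 3 (within the scatter). The earlier compounds shown here showed only an exchange of one group on the same ring, whereas these steps replace the whole aromatic group with one carrying two fluorine atoms, and the read-out still does not move beyond the scatter, with all three compounds remaining weak at the concentration tested. No supporting data are available to explain this result.

The compounds shown leave open whether any group on this carbonyl carbon can produce a step beyond the scatter, such as a pyridine ring, a carboxylic acid on the phenyl ring or a longer alkyl chain. They also do not show whether a change elsewhere on the shared core would do so.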